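From fluoro to hydroxy on an aromatic ring

This account rests on a few compounds, and the source may have more. Where it says the series, first, only, none or still open, it means among the compounds named here.

Two related compounds have been tested so far in a functional assay on U2OS cells (Homo sapiens) for inhibition, read by trypan blue exclusion, with a stated time of 72 h; a lower number here means a stronger inhibitor of growth, a higher number a weaker inhibitor of growth. In this test, compound 1 `Cn1c(=O)c(S(=O)(=O)c2ccc(OC(=O)CCCCC3SCC4NC(=O)NC43)cc2)cc2cnc(Nc3ccc4[nH]ccc4c3)nc21` gives 350 nM, while compound 2 `Cn1c(=O)c(S(=O)(=O)c2ccc(F)cc2)cc2cnc(Nc3ccc4[nH]ccc4c3)nc21` gives 55 nM. Compound 2 therefore has the lower of the two numbers, and the gap between them is larger than the usual scatter of repeated measurements.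

The next compound, compound 3 `Cn1c(=O)c(S(=O)(=O)c2ccc(O)cc2)cc2cnc(Nc3ccc4[nH]ccc4c3)nc21`, keeps the structure of compound 2 except for one small change: hydroxy in place of fluoro on an aromatic carbon. The group sits para to a large group, and the change turns 4-fluorophenyl into 4-hydroxyphenyl.

Within the data shown here, no measured pair shows this exact swap, so any forecast is loose. The nearest guide is compound 1, which has a long ester attached through oxygen on that same aromatic carbon and gives 350 nM. A small loss of growth inhibition, perhaps no larger than the scatter, is therefore expected, and the estimated change is a 1.8-fold higher number from compound 2 to compound 3 (0.26 log units; within the scatter). Compound 3 is expected to give about 100 nM, with an estimated range from 30 nM to 330 nM.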

Compound 3, concentration for 50% growth inhibition: 350 nM
Compound 3: the middle estimate sits 3.5-fold (0.54 log units) below what was measured; the measured number lies above the stated range.
By their numbers in this assay, from the lowest: compound 2; then compounds 1 and 3 (each within the scatter of the next).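

Exchanging fluoro for hydroxy on this aromatic carbon gives, in this assay, a 6.4-fold higher number from compound 2 to compound 3 (0.80 log units; beyond the scatter), so this position is not indifferent to the change, even though one heavy atom simply replaces another. Here the swap is read directly for the first time, rather than inferred from the large ester of compound 1. The free hydroxy of compound 3 gives 350 nM, and compound 1, which differs from it only by the long ester on that same oxygen, gives 350 nM, so in this assay, the two compounds cannot be told apart.

The compounds shown leave open whether fluoro is especially favourable at this carbon or hydroxy especially unfavourable, as a plain hydrogen, a methoxy group, an amine or a carboxylic acid in the same place would be needed to separate those two readings. The numbers record the size of the step, but no measurement offered here accounts for it.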